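A few compounds are considered here, and "the series" means these few. Any claim that something is new, unique, unknown or untested is made for them only; others in the source may bear on it.

Compound 1 `O=S(=O)(Nc1ccc(-c2nc3ccccc3o2)cc1)c1cccc(Cl)c1`: in an assay on isolated protein for inhibition of malate dehydrogenase, mitochondrial (Sus scrofa), with stated times of 45 min and 30 min (on this read-out higher numbers stand for weaker inhibition and lower numbers for stronger inhibition), compound 1 gives only a limit, > 63000 nM.
Compound 2 `COc1cccc(S(=O)(=O)Nc2ccc3oc(-c4ccccc4)nc3c2)c1`: in this assay compound 2 gives only a limit, > 63000 nM.
Compound 3 `O=S(=O)(Nc1ccc(-c2nc3ccccc3o2)cc1)c1ccccc1O`: in this assay compound 3 gives only a limit, > 63000 nM.

Among the measured compounds shown here, every value in this assay so far is a limit and not a number, (the limit of > 63000 nM in this assay, at which 3 of the 3 values shown sit). For the measured compounds named here, compound 2 therefore stands at that limit, and the two remaining values stand there with it, so no measured compound can be called stronger or weaker than another. Going by the values given here, the single step between compounds that differ in one place, a step that the two limits leave unreadable from compound 1 to compound 3, has no readable size, since both of its ends are limits.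

Compound 4 `O=S(=O)(Nc1ccc2oc(-c3ccccc3)nc2c1)c1ccc(O)cc1` is not yet measured. It differs from compound 2 in one place: 4-hydroxyphenyl in place of 3-methoxyphenyl on a sulfonyl sulfur. Among the compounds with values here, no measured step covers a change of this kind, and the only step recorded gives no size at all. The expectation for the step from compound 2 to compound 4 is thus no readable change beyond the scatter, a step that the limit leaves unreadable from compound 2 to compound 4, with a high chance that this assay again reports only a limit. Compound 4 is estimated at 100000 nM in this assay, in a range from 40000 nM to 300000 nM.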

Compound 4, half-maximal inhibitory concentration: > 63000 nM
Compound 4: no number, only a limit; the forecaster's own chance of this, stated with the estimate: 85%; the middle value lies beyond the limit too.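

The step from compound 2 to compound 4 has no readable size, and neither does any other step among these compounds, because both of its ends are limits: the limit of > 63000 nM in this assay, at which 4 of the 4 values shown sit.

The compounds shown leave open whether any of them has a measurable half-maximal inhibitory concentration in this assay and how the groups on the sulfonyl sulfur would rank if one did.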